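A few compounds are considered here, and "the series" means these few. Any claim that something is new, unique, unknown or untested is made for them only; others in the source may bear on it.

Compound 1 `Nc1cc(N)c2nc(-c3ccccc3)c(Oc3ccc(Cl)c(Cl)c3)nc2c1` in a functional assay on CAKI-1 cells (Homo sapiens) for inhibition, read by sulforhodamine B assay, with a stated time of 48 h (on this read-out higher numbers stand for lower toxicity in this test and lower numbers for higher toxicity in this test), gives < 100000 nM, which is a limit of the test rather than a measured number.
Compound 2 `Nc1cc(N)c2nc(-c3ccccc3)c(NCc3ccc(Cl)c(Cl)c3)nc2c1` in this assay gives < 100000 nM, again a limit and not a number.
Compound 3 `CCOC(=O)[C@H](CCC(=O)O)NC(=O)c1ccc(Sc2nc3cc(N)cc(N)c3nc2-c2ccccc2)cc1` in this assay gives < 100000 nM, also a limit.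

Compound 1 therefore stands nowhere in particular among the numbers shown: every result for the three measured compounds is a limit, and compound 1 shares that position, as the one recurring observation makes clear (the limit of < 100000 nM in this assay, at which 3 of the 3 values shown sit). Within the data shown here, no two measured compounds differ in one place only, so the measured set gives no step from which the effect of a single change on this read-out could be taken.

Compound 4 `Nc1cc(N)c2nc(-c3ccccc3)c(Sc3ccc(F)cc3)nc2c1` is the compound to be measured. It differs from compound 1 in one place: (4-fluorophenyl)sulfanyl in place of 3,4-dichlorophenoxy on an aromatic carbon. Among the measured compounds shown here, with no measured step to rest on, the expected step that the limit leaves unreadable from compound 1 to compound 4 is taken as none beyond the usual scatter of the test, in either direction. Compound 4 is accordingly expected to give about 30000 nM in this assay, within a range from 5000 nM to 100000 nM, and quite possibly the result will once more be reported only as a limit.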

Compound 4, concentration lethal to 50% of the cells: < 100000 nM
Compound 4: no number, only a limit; the forecaster's own chance of this, stated with the estimate: 70%; the middle value does not contradict the limit.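

In this assay, compound 1 and compound 4 are each reported only as a limit of the test and not as a number, so no step between them can be read: the limit of < 100000 nM in this assay, at which 4 of the 4 values shown sit.

The compounds shown leave open what actual number each would give, and so whether exchanging 3,4-dichlorophenoxy for (4-fluorophenyl)sulfanyl changes this read-out at all.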